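The compounds below may be only part of what the source reports. "The series", "measured", "known", "first", "only" and "open" are said of these compounds alone.

Values in a functional assay on HCT-116 cells (Homo sapiens) for inhibition, read by MTT assay, with a stated time of 48 h; a lower number here means a stronger inhibitor, a higher number a weaker inhibitor:

compound 1 `COc1cc2ccc(=O)oc2cc1OC(=O)c1c(C)noc1-c1ccc(Cl)cc1`: 10900 nM
compound 2 `COc1cc2ccc(=O)oc2cc1OC(=O)c1c(C)noc1-c1ccccc1`: 22700 nM
compound 3 `COc1cc2ccc(=O)oc2cc1OC(=O)c1c(-c2ccc(Cl)cc2)n[nH]c1C`: 13800 nM

Compound 3 sits close to compound 1, the gap lying within the scatter, and its gap to compound 2 is likewise within the scatter; on these numbers compound 3 is not separated from either of the other two. Within the data shown here, the only step measured so far is a 2.1-fold higher number from compound 1 to compound 2 (0.32 log units; beyond the scatter), which shows a modest weakening on going from chloro to hydrogen.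

Compound 4 `COc1cc2ccc(=O)oc2cc1OC(=O)c1c(-c2ccccc2)n[nH]c1C` is the next member. It differs from compound 3 by hydrogen in place of chloro on an aromatic carbon. Among the measured compounds shown here, this is the same change as the one taken from compound 1 to compound 2, carried out on the core of compound 3 instead. That step is the only measured one bearing on it, so a step of similar size and direction is expected here, that is a 2.0-fold higher number from compound 3 to compound 4 (0.31 log units; beyond the scatter). Compound 4 is therefore expected to give about 28000 nM in this assay, with a likely range of 13000 nM to 60000 nM.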

Compound 4, half-maximal inhibitory concentration: > 25000 nM
Compound 4 gave a limit, no number; the forecaster's own chance of this, stated with the estimate: 10%; the middle value is on the limit's open side.
By their numbers in this assay, from the lowest: compounds 1, 3 and 2 (each within the scatter of the next, the first and the last beyond it). At a limit, above all of these: compound 4.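

In this assay, compound 4 gives > 25000 nM, which is a limit of the assay and not a number. Going from 4-chlorophenyl to phenyl gives an at least 1.8-fold higher number from compound 3 to compound 4 (0.25 log units; that floor lies within the scatter), so the floor alone does not separate this pair, though its direction agrees with the step on the core of compound 1. The change at this position has now been read on two cores, and its size on the second stays unfixed: the same change on two cores in this assay, a 2.1-fold higher number (0.32 log units; beyond the scatter) from compound 1 to compound 2 and an at least 1.8-fold higher number (0.25 log units; that floor lies within the scatter) from compound 3 to compound 4; the limit leaves it open whether they differ

The compounds shown carry only chloro or hydrogen at this place on the ring, so the effect of a methoxy group, an amine or a carboxylic acid there stays open. On these data alone, how far compound 4 lies past its limit also stays open, and with it whether the step has the same size on both cores.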